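Chloro for methyl on the sulfonate aryl group

The source may report more compounds than this note shows. Statements on the series, on what has been measured and on what is new or still open speak of the compounds shown alone.

Measured so far:
Compound 1 `N#C/C(=C\c1ccccc1OS(=O)(=O)c1ccc(Cl)cc1)C(=O)Nc1nnc(-c2cccc(F)c2)s1`: 71%
Compound 2 `Cc1ccc(Cc2nnc(NC(=O)/C(C#N)=C/c3ccccc3OS(=O)(=O)c3ccc(C)cc3)s2)cc1`: 66%

In a functional assay on RS4-11 cells (Homo sapiens) for inhibition, read by CCK-8 assay, with a stated time of 48 h, tested at 20 uM (a lower number here means less inhibition of growth, a higher number more inhibition of growth at the concentration tested), compound 2 gives 66%, which lies within the scatter of compound 1 at 71%. The next compound, compound 3 `Cc1ccc(Cc2nnc(NC(=O)/C(C#N)=C/c3ccccc3OS(=O)(=O)c3ccc(Cl)cc3)s2)cc1`, follows from compound 2 by one change chloro in place of methyl on an aromatic carbon, turning (4-methylphenyl)sulfonyl into (4-chlorophenyl)sulfonyl. Among the measured compounds shown here, no measured pair shows this change on its own, so the data give no direct size for it. With only these two values to go on, no change beyond the scatter is expected in this assay. The estimated move is small, a number 2 percentage points higher from compound 2 to compound 3 (within the scatter). For compound 3 the expected value is 68%, with an estimated range of 55% to 80%.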

Compound 3, percent growth inhibition at one concentration: 72%
Estimate against measurement, compound 3: 4 percentage points below, within the range that was stated.
By their numbers in this assay, from the lowest: compounds 2, 1 and 3 (each within the scatter of the next).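

In this assay, among the compounds shown here, the exchange of methyl for chloro on the sulfonate aryl group gives a number 6 percentage points higher from compound 2 to compound 3 (within the scatter) and so provides the first direct reading of this change, which stays within the scatter with the 4-methylbenzyl group held constant. The other exchange, 4-methylbenzyl in place of 3-fluorophenyl with the (4-chlorophenyl)sulfonyl group held constant, gives a number 1 percentage points higher from compound 1 to compound 3 (within the scatter) and also stays within the scatter, so neither step separates these compounds at this single concentration. Nothing at hand offers an explanation for either step.

On these data alone, it remains open whether a methoxy group, an amine or a carboxylic acid in place of chloro would move growth inhibition beyond the scatter. A single concentration also leaves open whether full dose-response curves would separate compound 1, compound 2 and compound 3.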